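Spinach series: isopropyl for isobutyl on the para-hydroxyphenyl arm

The compounds below may be only part of what the source reports. "The series", "measured", "known", "first", "only" and "open" are said of these compounds alone.

Of the compounds shown here, three of one shared core have been measured. Compound 1 `CC(C)c1cnc(C(=O)/C=C/c2ccccc2O)cn1` gives 167000 nM in a functional assay on the whole organism for inhibition, with Spinacia oleracea as the target, read by spectrophotometry, with a stated time of 4 h; a lower number here means a stronger inhibitor, a higher number a weaker inhibitor. Compound 2 `CC(C)Cc1cnc(C(=O)/C=C/c2ccccc2O)cn1` gives 144000 nM in this assay, and compound 3 `CC(C)Cc1cnc(C(=O)/C=C/c2ccc(O)cc2)cn1` gives 235000 nM in this assay. The two changes between measured compounds are each small. The first is isopropyl in place of isobutyl on an aromatic carbon and gives a 1.2-fold higher number from compound 2 to compound 1 (0.06 log units; within the scatter). The second is 4-hydroxyphenyl in place of 2-hydroxyphenyl on a double-bonded chain carbon bound to a double-bonded chain carbon and gives a 1.6-fold higher number from compound 2 to compound 3 (0.21 log units; within the scatter). None of the three values can be set apart from the others; the numbers of compound 3 and compound 1 likewise lie within the scatter of each other.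

Compound 4 `CC(C)c1cnc(C(=O)/C=C/c2ccc(O)cc2)cn1` has not yet been measured in this assay. It differs from compound 3 by isopropyl in place of isobutyl on an aromatic carbon, which is the same change already made from compound 2 to compound 1, at the same place on the same kind of ring. The two cores differ in how the hydroxyphenyl is joined, as told by 4-hydroxyphenyl in place of 2-hydroxyphenyl on a double-bonded chain carbon bound to a double-bonded chain carbon.

The expectation for compound 4 rests on compound 1 and compound 2 because a 1.2-fold higher number from compound 2 to compound 1 (0.06 log units; within the scatter) was within the scatter; the step from compound 3 to compound 4 is expected to be a 1.2-fold higher number from compound 3 to compound 4 (0.08 log units; within the scatter), set beside that earlier one. Compound 4 is therefore estimated at 280000 nM in this assay, with an expected range from 150000 nM to 550000 nM.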

Compound 4, half-maximal inhibitory concentration: 315000 nM
For compound 4 the middle estimate is 1.1-fold (0.05 log units) below the measured one; the range from low to high includes it.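

In this assay, isopropyl in place of isobutyl on an aromatic carbon gives a 1.3-fold higher number from compound 3 to compound 4 (0.13 log units; within the scatter) on the core carrying the 4-hydroxyphenyl, and the comparison with the same change on the core carrying the 2-hydroxyphenyl reads: the same change on two cores in this assay, a 1.2-fold higher number (0.06 log units; within the scatter) from compound 2 to compound 1 and a 1.3-fold higher number (0.13 log units; within the scatter) from compound 3 to compound 4, 1.2-fold (0.06 log units) apart, within the scatter of two such steps

On these two cores the change therefore carries over with no difference that can be detected, and the step seen on one core would have served as a fair guide to the step on the other. Among the compounds shown here, this does not show that the change itself has any effect on either core, since each step on its own lies within the scatter, so the agreement is between two steps that cannot be told from no step at all; nor does it show that a larger step would carry over in the same way, and two cores are a narrow basis for any rule about the series.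

Still open, on these data alone, is whether a group further from isobutyl and isopropyl on this aromatic carbon, such as a longer chain, an amine or a carboxylic acid, would give a step beyond the scatter. Also open, as far as these compounds go, is whether such a step would then hold across both the 2-hydroxyphenyl and 4-hydroxyphenyl cores, or on a core with a methoxy group in place of the hydroxyl.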